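A few compounds are considered here, and "the series" means these few. Any claim that something is new, unique, unknown or untested is made for them only; others in the source may bear on it.

Of the compounds shown here, two carry a number so far. Compound 1 `CCc1nc2sccn2c1/C=N/OCc1ccc(Cl)c(Cl)c1` is the starting point of the step reviewed here; in an assay on HepG2 cells for agonist activity at nuclear receptor subfamily 1 group I member 3 (Homo sapiens), read by a luciferase reporter, with a stated time of 23 h (a lower number here means that less compound is needed, a higher number that more compound is needed for the effect), compound 1 gives 2600 nM, the higher of the two values. Compound 2 `FC(F)(F)c1ccc(CO/N=C/c2c(-c3ccc4ccccc4c3)nc3occn23)cc1` differs from compound 1 in several places. In this assay compound 2 gives 470 nM, a lower number beyond the usual scatter. Within the data shown here, no single-change step joins the two, so the pair shows only that an analogue carrying an aryl group at that part of the core can reach a lower number.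

Compound 3 `Fc1ccc(-c2nc3sccn3c2/C=N/OCc2ccc(Cl)c(Cl)c2)cc1` is not yet measured. Relative to compound 1 the change is 4-fluorophenyl in place of ethyl on an aromatic carbon The shared core and the dichlorobenzyl oxime ether are unchanged, so any shift rests on the 4-fluorophenyl alone.

Among the measured compounds shown here, no measured step of this kind exists in the set. Resting on compound 2 at 470 nM, the expectation for compound 3 is a lower number, by an estimated step of a 3.3-fold lower number from compound 1 to compound 3 (0.51 log units; beyond the scatter), beyond the scatter. The estimate for compound 3 in this assay is 800 nM, within 250 nM to 2500 nM.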

Compound 3, half-maximal effective concentration: 670 nM
Compound 3: middle estimate off by 1.2-fold (0.08 log units), on the high side, and the stated range covers the measured number.
By their numbers in this assay, from the lowest: compounds 2 and 3 (each within the scatter of the next); then compound 1.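

Replacing ethyl with 4-fluorophenyl on an aromatic carbon, with the shared core and the dichlorobenzyl oxime ether held constant, gives a 3.9-fold lower number from compound 1 to compound 3 (0.59 log units; beyond the scatter) in this assay as the series' first single-change step. Among these compounds, the earlier pair differed in several places, so it could not separate the aryl group from its other differences, whereas this shift rests on the one exchange at this position, on the ring carbon next to the ring nitrogen. The data give no measured basis for explaining the shift.

Still open, as far as these compounds go, is whether the fluorine contributes to this step, a question that unsubstituted phenyl at the same place would address, and whether the aromatic ring is required, which cyclohexyl or a longer chain such as butyl would test. Also open, from the compounds shown here alone, is how far this position accepts a different kind of substituent, such as an amine or a carboxylic acid on the phenyl ring, and whether the same exchange gives a step of similar size when the dichlorobenzyl oxime ether is replaced.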